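Solubility notes on a quinoline diamine series, compound 4 pending

The source may hold more compounds than are shown below. What is called first, only, known or untested is meant among the compounds shown, and "the series" means these compounds.

The measured set comprises compound 1 `COc1ccc(F)cc1CNCCCNc1ccnc2cc(Cc3cc(C)cc(C)c3)ccc12`, compound 2 `CC(C)CCc1ccc2c(NCCCNCc3ccco3)ccnc2c1` and compound 3 `CCC(CC)c1ccc2c(NCCCNCc3cccc(OC)c3O)ccnc2c1`, each examined in a physicochemical assay for solubility, with a stated time of 18 h, at pH 7.4; a lower number here means a less soluble compound, a higher number a more soluble compound. In this assay compound 1 gives 4200 nM. In this assay compound 2 gives 4200 nM, and compound 3 gives 4200 nM. Compound 1 therefore stands level with both companions at the digits shown: the nearest, compound 2, shows no change within the scatter, and the furthest, compound 3, likewise shows none. For the measured compounds named here, the three differ widely in the group on the shared core, yet the read-out is flat across them, so no step between measured pairs can be drawn from these data.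

Compound 4 `COc1ccc(F)cc1CNCCCNc1ccnc2cc(CCc3ccccc3)ccc12` has not yet been measured in this assay. The change from compound 1 is benzyl in place of 3,5-dimethylphenyl on a saturated chain carbon bound to an aromatic carbon. With every measured compound sitting at the same reading, no basis exists for expecting a shift beyond the scatter here. The expected step from compound 1 to compound 4 in this assay is no change at the digits printed from compound 1 to compound 4 (within the scatter), which amounts to no change beyond the scatter. Compound 4 is accordingly estimated at 4200 nM, with a range from 2000 nM to 9000 nM.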

Compound 4, solubility: 4200 nM
Compound 4: middle estimate and measured number agree at the digits printed; the range from low to high includes it.
By their numbers in this assay, from the lowest: compounds 1, 2, 3 and 4 (each within the scatter of the next).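

For the compounds shown here, this is the first comparison that differs in one place only: compounds 2 and 3 differ from compound 1 in more than one place, so their matching readings could not isolate any single group. In this assay, benzyl in place of 3,5-dimethylphenyl on a saturated chain carbon bound to an aromatic carbon gives no change at the digits printed from compound 1 to compound 4 (within the scatter), so this particular swap, which also reads as 3,5-dimethylbenzyl to phenethyl, leaves the reading within the scatter. The groups are closely matched, with 8 carbon atoms leaving and 7 entering, each group holding one six-membered aromatic ring of carbon only and neither holding hydrogen-bond donors or acceptors, and no measured property is available to explain the result at this position.

The compounds shown leave open how a carboxylic acid or a tertiary amine at this place, or a chain longer than phenethyl, would read in this assay. Both groups compared here carry the same kind of ring. The result says nothing about a group with nitrogen or oxygen in its ring, such as pyridyl or morpholinyl, at this place.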